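Acylhydrazide variants of a dihydropyridine in rat paw edema

The source may hold more compounds than are shown below. What is called first, only, known or untested is meant among the compounds shown, and "the series" means these compounds.

Measured compounds:
compound 1 `CCOC(=O)C1=C(C)NC(C)=C(C(=O)OCC)C1c1ccc(OCC(=O)NCc2ccccc2)cc1` — 16.1%
compound 2 `CCOC(=O)C1=C(C)NC(C)=C(C(=O)OCC)C1c1ccc(OCC(=O)NNC(=O)c2ccc(C)cc2)cc1` — 35.9%

Both compounds share a core on which an aryloxyacetamide arm carries the variable group. In a functional assay on the whole organism (strain Wistar) for inhibition, with Rattus norvegicus as the target, read by paw edema, with stated times of 30 min and 1 h, at a dose of 20 mg/kg (a higher number here means more inhibition at the dose given (going by the name of the read-out), a lower number less inhibition), compound 1 gives 16.1%, and compound 2 gives 35.9%. Within the data shown here, the one step recorded, a number 19.8 percentage points higher from compound 1 to compound 2 (beyond the scatter), lies beyond the scatter, so compound 2 stands higher of the two numbers.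

Compound 3 `CCOC(=O)C1=C(C)NC(C)=C(C(=O)OCC)C1c1ccc(OCC(=O)NNC(=O)c2ccsc2Cl)cc1` has not yet been measured. It differs from compound 2 in one place: 2-chlorothiophen-3-yl in place of 4-methylphenyl on a carbonyl carbon. Among the measured compounds shown here, the only step recorded concerns a change on the amide-type nitrogen, not on this carbonyl carbon, so it bears on the new step only loosely, by showing that the tail region can move the number by a modest amount. For the measured compounds named here, no step tells how a change on the carbonyl carbon acts. Compound 3 is therefore expected to sit close to compound 2, with a step of a number 2.9 percentage points lower from compound 2 to compound 3 (within the scatter), within the scatter. The estimate for compound 3 is 33%, from 20% to 46%.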

Compound 3, a percentage reported as inhibition, in the whole organism at one dose (the size of the read-out at that dose, not a potency): 42.3%
For compound 3 the middle estimate is 9.3 percentage points below the measured one; low and high end bracket the measured number.
By their numbers in this assay, from the lowest: compound 1; then compounds 2 and 3 (each within the scatter of the next).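

In this assay, the change on the carbonyl carbon gives a number 6.4 percentage points higher from compound 2 to compound 3 (within the scatter), so a five-membered aromatic ring with 1 hetero atom, carrying chlorine, cannot be told apart from 4-methylphenyl at this position, and the read-out does not depend on the six-membered aromatic ring of carbon only being there. The gap to the benzyl amide also holds with this new group, at a number 26.2 percentage points higher from compound 1 to compound 3 (beyond the scatter), so on the amide-type nitrogen both acyl groups shown stand clear of benzyl, while the two differ from each other by no more than the scatter. No measurement here explains either step.

The two aromatic groups on the carbonyl carbon leave open whether an aromatic ring is needed there at all, since a non-aromatic group such as cyclohexyl or a simple methyl, or a ring carrying a carboxylic acid or an amine, could behave differently. Each number also comes from a single dose, so these compounds leave open whether compound 2 and compound 3 would still match at other doses.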